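The source may report more compounds than this note shows. Statements on the series, on what has been measured and on what is new or still open speak of the compounds shown alone.

Compound 3, `CC(C)[C@H](NC(=O)COc1cccc2ccccc12)C(=O)N[C@@H](CC(=O)O)C(=O)CSc1nnnn1C`, is the starting point of this step. In a functional assay on Jurkat cells (Homo sapiens) for inhibition (a lower number here means a stronger inhibitor, a higher number a weaker inhibitor), compound 3 gives > 200000 nM, which is a limit of the assay rather than a number. Its neighbours share the same core and differ only in the group on a sulfur. Compound 1, `CC(C)[C@H](NC(=O)COc1cccc2ccccc12)C(=O)N[C@@H](CC(=O)O)C(=O)CSc1nc(-c2ccccc2)cs1`, gives > 200000 nM in this assay, again a limit. Compound 2, `CC(C)[C@H](NC(=O)COc1cccc2ccccc12)C(=O)N[C@@H](CC(=O)O)C(=O)CSc1nnc(-c2ccccc2)o1`, gives 150000 nM in this assay. The measured steps are all small: an at least 1.3-fold lower number from compound 1 to compound 2 (0.12 log units; that floor lies within the scatter), an at least 1.3-fold higher number from compound 2 to compound 3 (0.12 log units; that floor lies within the scatter) and a step that the two limits leave unreadable from compound 1 to compound 3. Compound 3 thus sits at the limit of > 200000 nM in this assay, at which 2 of the 3 values shown sit. Compound 4, `CC(C)[C@H](NC(=O)COc1cccc2ccccc12)C(=O)N[C@@H](CC(=O)O)C(=O)COc1cc(C(F)(F)F)ncn1`, is not yet measured; it differs from compound 3 by (6-(trifluoromethyl)pyrimidin-4-yl)oxy in place of (1-methyl-1H-tetrazol-5-yl)sulfanyl on a saturated chain carbon bound to a carbonyl carbon. Among the measured compounds shown here, none of the measured steps makes this kind of change, so they bear on it only by showing that swapping the ring on this saturated chain carbon bound to a carbonyl carbon moved this assay little. Compound 4 is therefore expected to remain near the limit, with an expected step of an at least 1.6-fold lower number from compound 3 to compound 4 (0.22 log units; that floor lies within the scatter). The estimate for compound 4 is 120000 nM, with an expected range from 30000 nM to 250000 nM.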

Compound 4, half-maximal inhibitory concentration: > 200000 nM
Compound 4: no number, only a limit (the forecaster's own chance of this, stated with the estimate: 50%); middle value at least 1.6-fold (0.22 log units) from the limit.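

With the (6-(trifluoromethyl)pyrimidin-4-yl)oxy group, compound 4 also gives only a limit in this assay, so on this saturated chain carbon bound to a carbonyl carbon, a change from a sulfur link to an oxygen link and from a five-membered to a six-membered ring yields no readable gain. Among the compounds shown here, the one readable step is an at least 1.3-fold higher number from compound 2 to compound 4 (0.12 log units; that floor lies within the scatter); the other new steps cannot be read. An oxygen-linked ring now stands with the sulfur-linked rings of compound 1 and compound 3 at the ceiling: the limit of > 200000 nM in this assay, at which 3 of the 4 values shown sit.

As far as these compounds go, how far compound 1, compound 3 and compound 4 lie beyond that limit remains open, and with it any order among them. Also open, from the compounds shown here alone, is whether a fluorine atom or an amine on this saturated chain carbon would give a measurable number in this assay.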